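A few compounds are considered here, and "the series" means these few. Any claim that something is new, unique, unknown or untested is made for them only; others in the source may bear on it.

Working notes on a series of three measured compounds that share one core and differ only in the aryl group on an aromatic carbon. In a functional assay on the whole organism (strain albino) for inhibition, with Rattus norvegicus as the target, read by paw edema, with stated times of 30 min and 3 h, at a dose of 0.28 mmol/kg by the oral route (on this read-out lower numbers stand for less inhibition and higher numbers for more inhibition at the one dose given (going by the name of the read-out)), compound 1 `COc1cc(-c2nnc(SCC(=O)Nc3ccc(/C(C)=N/O)cc3)n2-c2ccccc2)cc(OC)c1OC` gives 66%. Compound 2 `C/C(=N\O)c1ccc(NC(=O)CSc2nnc(-c3ccccc3)n2-c2ccccc2)cc1` gives 63% in this assay, and compound 3 `COc1ccc(-c2nnc(SCC(=O)Nc3ccc(/C(C)=N/O)cc3)n2-c2ccccc2)cc1` gives 57% in this assay. Compound 2 stands second highest of the three numbers, with compound 1 nearest and compound 3 furthest; both gaps lie within the scatter, as does the remaining pair: a number 3 percentage points lower from compound 1 to compound 2 (within the scatter), a number 6 percentage points lower from compound 2 to compound 3 (within the scatter), a number 9 percentage points lower from compound 1 to compound 3 (within the scatter). Nothing in these three numbers separates the compounds from one another.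

Compound 4 `CCn1c(SCC(=O)Nc2ccc(/C(C)=N/O)cc2)nnc1-c1ccccc1` is not yet measured. It differs from compound 2 in one place: ethyl in place of phenyl on an aromatic nitrogen. Going by the values given here, no measured step touches the group on the aromatic nitrogen; all three steps exchange the aryl on the aromatic carbon, so none of them bears directly on this change. What the series does show is that every exchange made so far left this assay within the scatter. Among the compounds with values here, with no step of its own kind to draw on, the working expectation is no step beyond the scatter in either direction, a number 5 percentage points lower from compound 2 to compound 4 (within the scatter). Compound 4 is therefore estimated at 58%, within a range of 42% to 72%.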

Compound 4, a percentage reported as inhibition, in the whole organism at one dose (the size of the read-out at that dose, not a potency): 65%
For compound 4 the middle estimate is 7 percentage points below the measured one; low and high end bracket the measured number.
By their numbers in this assay, from the lowest: compounds 3, 2, 4 and 1 (each within the scatter of the next).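

Going by these compounds alone, compound 4 brings the first change on the aromatic nitrogen, and in this assay ethyl in place of phenyl gives a number 2 percentage points higher from compound 2 to compound 4 (within the scatter) even though a group of 6 heavy atoms with a six-membered aromatic ring gives way to one of 2 heavy atoms with no ring. The insensitivity seen so far for the aryl on the aromatic carbon therefore also holds for this one exchange on the aromatic nitrogen, so at the one dose given, a phenyl group at this place is not needed to keep the number within the scatter of compound 2. No measurement at hand gives a reason for this result.

With only phenyl and ethyl shown on the aromatic nitrogen, it remains open how hydrogen, a longer chain such as butyl, or a chain ending in an amine or a carboxylic acid would read in this assay. Also open, as far as these compounds go, is whether ethyl on the nitrogen combined with 3,4,5-trimethoxyphenyl or 4-methoxyphenyl on the aromatic carbon would stay within the scatter, and how these compounds would separate across a range of doses.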